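Compound 3 to compound 4: ethyl gives way to 4-nitrophenyl

A few compounds are considered here, and "the series" means these few. Any claim that something is new, unique, unknown or untested is made for them only; others in the source may bear on it.

Of the compounds shown here, three have so far been read in a toxicity assay on GES1 cells (Homo sapiens) for inhibition, read by MTT assay, with a stated time of 72 h (a higher number here means a weaker inhibitor, a lower number a stronger inhibitor), and they differ in one group. Compound 1 `Cc1cc(N2CC[C@@H](C)[C@@H](N(C)c3ncnc4[nH]ccc34)C2)n2nc(SCc3ccc(Cl)cc3)nc2n1` carries a 4-chlorophenyl on a saturated chain carbon bound to a sulfur and gives > 100000 nM as its reading, which is a limit of the assay and not a number. Compound 2 `Cc1cc(N2CC[C@@H](C)[C@@H](N(C)c3ncnc4[nH]ccc34)C2)n2nc(SCC3CC3)nc2n1` has cyclopropyl at that place and gives 27900 nM as a true number. Compound 3 `CCCSc1nc2nc(C)cc(N3CC[C@@H](C)[C@@H](N(C)c4ncnc5[nH]ccc45)C3)n2n1` has ethyl there and gives 67100 nM as the higher of the two true numbers. Its nearest neighbour sets the gap, since a 2.4-fold higher number from compound 2 to compound 3 (0.38 log units; beyond the scatter) is what separates them.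

Compound 4 `Cc1cc(N2CC[C@@H](C)[C@@H](N(C)c3ncnc4[nH]ccc34)C2)n2nc(SCc3ccc([N+](=O)[O-])cc3)nc2n1` alters this same group, and 4-nitrophenyl in place of ethyl on a saturated chain carbon bound to a sulfur sums up the change: 4-nitrophenyl in place of ethyl on a saturated chain carbon bound to a sulfur. Read backward, an at least 1.4-fold lower number from compound 1 to compound 3 (0.17 log units; that floor lies within the scatter) suggests a rise when a substituted phenyl enters at this place, but its floor lies within the scatter. Compound 1 is the only such phenyl case, and an at least 3.5-fold lower number from compound 1 to compound 2 (0.55 log units; beyond the scatter) points the same way with cyclopropyl rather than ethyl as the partner. A small upward move is therefore expected, and the estimated 1.3-fold higher number from compound 3 to compound 4 (0.10 log units; within the scatter) stays within the scatter. In this assay compound 4 is expected near 85000 nM with an estimated range from 30000 nM to 150000 nM and the reading could also end up as a limit.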

Compound 4, half-maximal inhibitory concentration: 36600 nM
The estimate for compound 4 lay 2.3-fold (0.37 log units) above the measured number; the measured number falls inside the stated range.
By their numbers in this assay, from the lowest: compounds 2, 4 and 3 (each within the scatter of the next, the first and the last beyond it). At a limit, above all of these: compound 1.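

In this assay, a substituted phenyl at this place does not by itself bring the reading to the limit, as nitro in place of chloro on an aromatic carbon gives an at least 2.7-fold lower number from compound 1 to compound 4 (0.43 log units; beyond the scatter). The 4-nitrophenyl group also cannot be told apart from either small group on a saturated chain carbon bound to a sulfur, with a 1.8-fold lower number from compound 3 to compound 4 (0.26 log units; within the scatter) and a 1.3-fold higher number from compound 2 to compound 4 (0.12 log units; within the scatter), even though ethyl and cyclopropyl themselves differ beyond the scatter. Compound 1 alone stands at a limit and not at a number, so the size of its step is only a floor: the limit of > 100000 nM in this assay, at which 1 of the 4 values shown sits.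

From the compounds shown here alone, what a methoxy group, an amine or a carboxylic acid on that aromatic carbon would read remains open, and so does an unsubstituted phenyl, so the chloro and nitro pair cannot yet be taken as a trend. Also open, going by these compounds, is how a longer chain, such as butyl or hexyl in place of ethyl, would read in this assay.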